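The source may report more compounds than this note shows. Statements on the series, on what has been measured and on what is new or still open speak of the compounds shown alone.

Among the compounds with values here, compound 1 `COc1cc(-n2cnc3ccc(-c4cccc(N)c4)cc32)cc(OC)c1OC` carries a 3-aminophenyl group on its core and gives 640 nM in a functional assay on A549 cells (Homo sapiens) for antiproliferative activity, read by MTT assay, with a stated time of 72 h (on this read-out higher numbers stand for weaker inhibition and lower numbers for stronger inhibition), the lowest of the two numbers measured so far. Compound 2 `COc1cccc(-c2ccc3ncn(-c4cc(OC)c(OC)c(OC)c4)c3c2)c1` gives 3180 nM in this assay, and the step of a 5.0-fold higher number from compound 1 to compound 2 (0.70 log units; beyond the scatter) shows that exchanging the amino group for methoxy weakens inhibition beyond the scatter. Compound 3 `COc1cc(-n2cnc3ccc(-c4ccccc4Cl)cc32)cc(OC)c1OC` has not yet been measured in this assay. It differs from compound 1 in one place: 2-chlorophenyl in place of 3-aminophenyl on an aromatic carbon. Within the data shown here, the only measured step that bears on this change is a 5.0-fold higher number from compound 1 to compound 2 (0.70 log units; beyond the scatter), in which the amino group was lost. Since the entering 2-chlorophenyl group also lacks that amino group, a step upward of similar size is expected for compound 3, namely a 4.7-fold higher number from compound 1 to compound 3 (0.67 log units; beyond the scatter). Compound 3 is therefore estimated at 3000 nM, with a range from 800 nM to 12000 nM.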

Compound 3, half-maximal inhibitory concentration: > 10000 nM
Compound 3 was reported as a limit; the forecaster's own chance of this, stated with the estimate: 5%; at least 3.3-fold (0.52 log units) between middle value and limit.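

Compound 3 is reported only as a limit of the assay, not as a number: the limit of > 10000 nM in this assay, at which 1 of the 3 values shown sits. Even so, this aromatic carbon proves sensitive to the group it carries, with 2-chlorophenyl in place of 3-aminophenyl giving an at least 15-fold higher number from compound 1 to compound 3 (1.19 log units; beyond the scatter). Losing the amino group does not settle the outcome on its own: neither compound 2 nor compound 3 has it, yet 2-chlorophenyl in place of 3-methoxyphenyl gives an at least 3.1-fold higher number from compound 2 to compound 3 (0.49 log units; beyond the scatter), so the groups without an amino group are not interchangeable here.

The change to compound 3 alters both the substituent and its place on the phenyl ring, and the compounds shown do not separate these two changes. Going by these compounds, whether the chlorine or its place counts for more stays open, as does how a 3-chlorophenyl, 2-aminophenyl or unsubstituted phenyl group would behave.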